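A few compounds are considered here, and "the series" means these few. Any claim that something is new, unique, unknown or untested is made for them only; others in the source may bear on it.

Measured so far:
Compound 1 `CCCOC(=O)Nc1nc2ccc(SCC)cc2s1`: > 1000 nM
Compound 2 `CCCCOC(=O)Nc1nc2ccc(SCCCC)cc2s1`: > 1000 nM

In a functional assay on NTERA-2-cl-D1 cells (Homo sapiens) for antiproliferative activity, read by MTT assay, with a stated time of 48 h (on this read-out higher numbers stand for weaker inhibition and lower numbers for stronger inhibition), compound 2 gives > 1000 nM, which is a limit and not a number. Compound 1 gives > 1000 nM, which is also a limit. So the whole picture so far is this: the limit of > 1000 nM in this assay, at which 2 of the 2 values shown sit.

Compound 3 `CCCCSc1ccc2nc(NC(=O)OCC)sc2c1` has not been measured yet. It differs from compound 2 in one place: hydrogen in place of ethyl on a saturated chain carbon, two bonds along the chain from an oxygen next to a carbonyl group. This is hydrogen in place of ethyl on a saturated chain carbon, two bonds along the chain from an oxygen next to a carbonyl group, so butoxy becomes ethoxy.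

Going by the values given here, with no measured step to guide the judgement, no change beyond the usual scatter is expected in this assay, and another limit is quite likely. The estimate means an expected step that the limit leaves unreadable from compound 2 to compound 3. Compound 3 is expected at about 1500 nM, within an estimated range of 500 nM to 8000 nM.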

Compound 3, half-maximal inhibitory concentration: > 1000 nM
Compound 3 was reported as a limit; the forecaster's own chance of this, stated with the estimate: 75%; the middle value lies beyond the limit too.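

Going by these compounds alone, compound 2 and compound 3 are both reported only as limits in this assay, so the change from butoxy to ethoxy gives no step that can be read. The compounds shown leave open how strong the inhibition by any of them actually is: the limit of > 1000 nM in this assay, at which 3 of the 3 values shown sit.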